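Branching the Chain on the Amine Nitrogen

This account rests on a few compounds, and the source may have more. Where it says the series, first, only, none or still open, it means among the compounds named here.

Of the compounds shown here, two sharing one core have been measured in a physicochemical assay for solubility, at pH 6.8; a higher number here means a more soluble compound, a lower number a less soluble compound. Compound 1 `CCCN(Cc1ccc(OC(F)(F)F)cc1)[C@@H]1COc2nc([N+](=O)[O-])cn2C1` carries a propyl chain on its amine nitrogen. In this assay compound 1 gives < 2 ug/mL, and this is a limit of the assay, not a number. Compound 2 `O=[N+]([O-])c1cn2c(n1)OC[C@@H](NCc1ccc(OC(F)(F)F)cc1Cl)C2` differs from compound 1 in more than one place, and in this assay compound 2 gives 30 ug/mL. For the measured compounds named here, no step between the two is worked out here, so only these two values stand.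

Compound 3 `CC(C)N(Cc1ccc(OC(F)(F)F)cc1)[C@@H]1COc2nc([N+](=O)[O-])cn2C1` has not yet been measured. The change from compound 1 to compound 3 is isopropyl in place of propyl on an amine nitrogen, with the same atoms joined differently. Swapping one three-carbon chain for another of the same size is expected to move solubility only little, and the expected step of a number no lower from compound 1 to compound 3 (the limit leaves the size open) lies within the usual scatter. Compound 3 is therefore estimated at 2 ug/mL, with a range from 0.5 ug/mL to 6 ug/mL, and the assay may again return only a limit.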

Compound 3, solubility: < 2 ug/mL
Compound 3: a limit, no number; the forecaster's own chance of this, stated with the estimate: 65%; the middle value sits exactly at the limit.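

For the compounds shown here, compound 1 and compound 3 each return only a limit of the assay, not a number, so no step between them can be read: the limit of < 2 ug/mL in this assay, at which 2 of the 3 values shown sit.

The compounds shown leave open how far apart compound 1 and compound 3 truly lie in this assay and which of the two sits higher.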